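The source may hold more compounds than are shown below. What is called first, only, known or untested is meant among the compounds shown, and "the series" means these compounds.

Measured so far:
Compound 1 `COc1ccc(CNCCCNS(=O)(=O)c2cc(C(F)(F)F)cc(C(F)(F)F)c2)cc1OC` gives 2800 nM in a functional assay on MIA PaCa-2 cells (Homo sapiens) for inhibition, read by MTT assay, with a stated time of 72 h; on this read-out lower numbers stand for stronger inhibition of growth and higher numbers for weaker inhibition of growth.
Compound 2 `O=S(=O)(NCCCCCCNCc1ccc(Br)cc1)c1cc(Cl)cc(Cl)c1` gives 12000 nM in this assay.

Of these two numbers, compound 1 has the lower one; compound 2 sits at a higher number, and the gap between them is beyond the usual scatter. Compound 3 `O=S(=O)(NCCCNCc1ccc(C(F)(F)F)cc1)c1cc(C(F)(F)F)cc(C(F)(F)F)c1` has not yet been measured. It keeps the core of compound 1 and changes one group: 4-(trifluoromethyl)phenyl in place of 3,4-dimethoxyphenyl on a saturated chain carbon bound to an amine nitrogen. Among the measured compounds shown here, no step between two measured compounds shows how this change behaves, so the expectation rests on compound 1 alone and on the kind of change made. Because compound 1 gives 2800 nM, the estimate for compound 3 is a step of a 1.4-fold lower number from compound 1 to compound 3 (0.15 log units; within the scatter), a small move toward a lower number that may well fall within the scatter. Compound 3 is therefore expected to give about 2000 nM, with a range from 700 nM to 6000 nM.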

Compound 3, concentration for 50% growth inhibition: 2500 nM
Compound 3: the middle estimate sits 1.3-fold (0.10 log units) below what was measured, within the range that was stated.
By their numbers in this assay, from the lowest: compounds 3 and 1 (each within the scatter of the next); then compound 2.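

In this assay putting 4-(trifluoromethyl)phenyl in place of 3,4-dimethoxyphenyl on a saturated chain carbon bound to an amine nitrogen gives a 1.1-fold lower number from compound 1 to compound 3 (0.05 log units; within the scatter) and so leaves the two compounds indistinguishable on this read-out. This pair gives the first view of this position: 3,4-dimethoxyphenyl has 2 hydrogen-bond acceptors and 4-(trifluoromethyl)phenyl has 0, yet the values match within the scatter, so in this pair those acceptors are not needed to keep the value. No independent evidence bears on why the two groups match.

This single pair leaves open how groups of another kind would behave at this position, such as a plain phenyl, a pyridine ring or a carboxylic acid. It also leaves open whether the same swap would give a similar result on a longer chain.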